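Methyl to methoxy on the pyridine of compound 1

A few compounds are considered here, and "the series" means these few. Any claim that something is new, unique, unknown or untested is made for them only; others in the source may bear on it.

Measured compounds:
compound 1 `Cc1ccc(Cn2c(=O)[nH]c3c(N)nc(C(F)(F)F)cc32)cn1` gives 2.3 in a physicochemical assay for lipophilicity, measured as octanol-water partition, at pH 7.4; on this read-out lower numbers stand for lower lipophilicity and higher numbers for higher lipophilicity
compound 2 `Cc1cccc(Cn2c(=O)[nH]c3c(N)nc(C(F)(F)F)cc32)n1` gives 2.3
compound 3 `Cc1nc(Cn2c(=O)[nH]c3c(N)nc(C(F)(F)F)cc32)co1` gives 1.7

Compound 1 and compound 2 stand level at the digits printed, together the highest of the three numbers, and the step of no change at the digits printed from compound 1 to compound 2 (within the scatter) lies within the scatter. Compound 3 sits lowest: the step of a number 0.60 log units lower from compound 1 to compound 3 (beyond the scatter) is modest but beyond the scatter, as is a number 0.60 log units lower from compound 2 to compound 3 (beyond the scatter).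

Compound 4 `COc1ccc(Cn2c(=O)[nH]c3c(N)nc(C(F)(F)F)cc32)cn1` is not yet measured. It differs from compound 1 by methoxy in place of methyl on an aromatic carbon. Among the compounds with values here, none of the measured steps touches this position; the measured steps only swap the whole pyridine or oxazole ring on the chain carbon, so they give no direct guide to a methyl-to-methoxy exchange. With nothing in the series speaking for a shift beyond the scatter, the step of no change at the digits printed from compound 1 to compound 4 (within the scatter) is expected to be small. Compound 4 is therefore estimated at 2.3, with a range from 1.9 to 2.7.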

Compound 4, distribution coefficient: 2.8
Estimate against measurement, compound 4: 0.50 log units below; measured number outside the range, above it.
By their numbers in this assay, from the lowest: compound 3; then compounds 1 and 2 (each within the scatter of the next); then compound 4.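

In this assay, within the data shown here, this position, on an aromatic carbon next to the ring nitrogen and para to a large group, proves responsive: methoxy in place of methyl gives a number 0.50 log units higher from compound 1 to compound 4 (beyond the scatter) and is the first exchange that leaves the ring itself unchanged. Against the other rings, 6-methoxypyridin-3-yl gives a number 0.50 log units higher from compound 2 to compound 4 (beyond the scatter) and also a number 1.10 log units higher from compound 3 to compound 4 (beyond the scatter) so the top of the series is now set by a single substituent and not by the choice of ring alone. No measurement at hand accounts for the direction of this step.

An ethyl group or an ethoxy group at the same place would show whether the step follows the oxygen or the added carbon count. As far as these compounds go, whether methoxy on the rings of compound 2 or compound 3 gives a similar step remains open.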